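The source may report more compounds than this note shows. Statements on the series, on what has been measured and on what is new or still open speak of the compounds shown alone.

In an ADME assay on microsomes from liver (Mus musculus) for metabolic stability, read by LC-MS, with a stated time of 30 min, tested at 1 uM (on this read-out higher numbers stand for a more stable compound and lower numbers for a less stable compound), compound 1 (`Cc1ccccc1S(=O)(=O)c1ccc(CNC(=O)c2cc3cnccc3[nH]2)cc1`) gives 15% while compound 2 (`O=C(NCc1ccc(S(=O)(=O)c2cccc(F)c2)cc1)c1cc2cnccc2[nH]1`) gives 44% and compound 3 (`O=C(NCc1ccc(S(=O)(=O)N2CCCCC2)cc1)c1cc2cnccc2o1`) gives 4.6% as the lowest of the three numbers, beyond the scatter from both others. Compound 4 (`O=C(NCc1ccc(S(=O)(=O)N2CCCCC2)cc1)c1cnc2nccn2c1`) differs from compound 3 in one place, with a group of 9 heavy atoms (6 carbon, 3 nitrogen; one five-membered aromatic ring with 2 hetero atoms, one six-membered aromatic ring with 2 hetero atoms) in place of a group of 9 heavy atoms (7 carbon, 1 nitrogen, 1 oxygen; one five-membered aromatic ring with 1 hetero atom, one six-membered aromatic ring with 1 hetero atom), on a carbonyl carbon and the rest of the structure unchanged. Among the compounds with values here, only one measured step is available, a number 29 percentage points higher from compound 1 to compound 2 (beyond the scatter) with 3-fluorophenyl in place of 2-methylphenyl on a sulfonyl sulfur. That step shows that one replacement can move this read-out beyond the scatter, but it lies at another place in the molecule, so its size offers only a loose guide. Within the data shown here, no measured pair isolates a change on the carbonyl carbon, since compound 3 differs from compound 1 and compound 2 in more than that one place. With compound 3 at 4.6% there is little room for a fall, so any movement is more likely to be upward. The estimated step is a number 7.4 percentage points higher from compound 3 to compound 4 (within the scatter) and a modest rise, possibly none beyond the scatter, is expected. For compound 4 the estimated value is 12% with an expected range from 2% to 35% in this measurement.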

Compound 4, percent of the compound remaining: 0.28%
Compound 4: middle estimate off by 11.7 percentage points, on the high side; the measured number lies below the stated range.
By their numbers in this assay, from the lowest: compounds 4 and 3 (each within the scatter of the next); then compound 1; then compound 2.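

Within the data shown here, on the carbonyl carbon, the first one-place change to be measured gives, in this assay, a number 4.3 percentage points lower from compound 3 to compound 4 (within the scatter) when the group with seven carbons, one nitrogen and one oxygen gives way to the group with six carbons and three nitrogens, so this replacement does not separate the two compounds on this read-out. The change keeps the ring sizes and the heavy-atom count and adds one hydrogen-bond acceptor, and that difference comes with no movement beyond the scatter, unlike a number 29 percentage points higher from compound 1 to compound 2 (beyond the scatter) on a sulfonyl sulfur elsewhere in the series. No measurement in hand bears on why the number stays where it does.

The compounds shown leave open whether a different group on this carbonyl carbon, such as a plain phenyl ring or an open-chain amine, would give a step beyond the scatter with the rest of compound 3 unchanged. They also leave open whether the same replacement on the carbonyl carbon would read alike in a compound carrying 3-fluorophenyl on the sulfonyl sulfur, as compound 2 does.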